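From 4-fluorophenyl to cycloheptyl on the shared core

The source may hold more compounds than are shown below. What is called first, only, known or untested is meant among the compounds shown, and "the series" means these compounds.

Compound 1 `CCOc1ccc(C2(c3ccc(O)cc3)C(=O)Nc3c2ccc(F)c3F)cc1`: 24 nM
Compound 2 `O=C1Nc2ccccc2C1(c1ccc(O)cc1)c1ccc(F)cc1`: > 1000 nM

In a functional assay on PC-3 cells (Homo sapiens) for cytotoxicity, read by WST assay, with a stated time of 72 h (on this read-out lower numbers stand for stronger inhibition and higher numbers for weaker inhibition), compound 1 gives 24 nM. Compound 2 gives > 1000 nM, which is a limit of the assay and not a number. Compound 3 `O=C1Nc2ccccc2C1(c1ccc(O)cc1)C1CCCCCC1` differs from compound 2 by cycloheptyl in place of 4-fluorophenyl on a saturated ring carbon. No measured exchange of this kind is available in this assay, so only a modest gain in strength is expected, with the reading staying close to that limit. The expected change is an at least 1.4-fold lower number from compound 2 to compound 3 (0.15 log units; that floor lies within the scatter). For compound 3 the estimated value is 700 nM, within an expected range of 120 nM to 3000 nM.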

Compound 3, half-maximal inhibitory concentration: > 1000 nM
Compound 3 was reported as a limit (the forecaster's own chance of this, stated with the estimate: 45%); middle value at least 1.4-fold (0.15 log units) from the limit.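

No step can be read between compound 2 and compound 3, because both stand at a limit and not at a number: the limit of > 1000 nM in this assay, at which 2 of the 3 values shown sit. On these data alone, how far cycloheptyl and 4-fluorophenyl differ in strength on the shared core stays open.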